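The source may report more compounds than this note shows. Statements on the series, on what has been measured and on what is new or still open speak of the compounds shown alone.

In an assay for displacement of a labelled ligand from Sigma non-opioid intracellular receptor 1 (Cavia porcellus), read by scintillation counting (on this read-out higher numbers stand for weaker inhibition and lower numbers for stronger inhibition), three compounds have been measured so far. Compound 1 `CC[C@@]1(c2ccccc2)OCC[C@@H](CCNC)O1` gives 856 nM, compound 2 `CC[C@@]1(c2ccccc2)OCC[C@@H](CCNCc2ccccc2)O1` gives 27 nM, and compound 3 `NCCC[C@@H]1CCO[C@H](c2ccccc2)O1` gives 167 nM, which is the second highest of the three numbers. Within the data shown here, the one step recorded between them, a 32-fold lower number from compound 1 to compound 2 (1.50 log units; beyond the scatter), concerns the amine end of the side chain and not the ring. Compound 4 `CC[C@@]1(c2ccccc2)OCC[C@@H](CCCN)O1` differs from compound 3 in a single place: ethyl in place of hydrogen on a saturated ring carbon. Among the measured compounds shown here, no measured step covers a change of this kind, so nothing here points in either direction, and the expected step is one not beyond the scatter, a 1.0-fold higher number from compound 3 to compound 4 (0.01 log units; within the scatter). Compound 4 is therefore estimated at 170 nM, within a range from 60 nM to 500 nM.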

Compound 4, inhibition constant: 6450 nM
Estimate against measurement, compound 4: 38-fold (1.58 log units) below; measured number outside the range, above it.
By their numbers in this assay, from the lowest: compound 2; then compound 3; then compound 1; then compound 4.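

In this assay, ethyl in place of hydrogen on this saturated ring carbon, between two ring oxygen atoms, is far from a neutral change: it gives a 39-fold higher number from compound 3 to compound 4 (1.59 log units; beyond the scatter) here. With the ethyl in place, the amine end of the side chain also counts, with a 7.5-fold higher number from compound 1 to compound 4 (0.88 log units; beyond the scatter) and a 240-fold higher number from compound 2 to compound 4 (2.38 log units; beyond the scatter) on this shared core. Nothing measured here explains these steps. Still open, going by these compounds, is whether methyl, propyl or a hydroxyl group on this ring carbon would give a step like that of ethyl.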